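The source may hold more compounds than are shown below. What is called first, only, known or untested is meant among the compounds shown, and "the series" means these compounds.

Measured so far in a functional assay on U-251 cells (Homo sapiens) for antiproliferative activity, read by MTT assay, with a stated time of 48 h; on this read-out higher numbers stand for weaker inhibition and lower numbers for stronger inhibition:
compound 1 `COc1ccc(-c2nc3cccc(-c4cc(OC)c(OC)c(OC)c4)c3o2)cc1F` gives 1700 nM;
compound 2 `COc1cc(-c2cccc3nc(-c4ccc(Br)cc4)oc23)cc(OC)c1OC` gives only a limit, > 25000 nM;
compound 3 `COc1cc(-c2cccc3nc(-c4ccc(C)cc4)oc23)cc(OC)c1OC` gives 3200 nM.

Compound 1 has the lowest of the two numbers, and the nearest is a 1.9-fold higher number from compound 1 to compound 3 (0.27 log units; within the scatter), so these two compounds cannot be ranked against each other. The value of compound 2 is a limit of this assay (the limit of > 25000 nM in this assay, at which 1 of the 3 values shown sits), and the step of an at least 14-fold higher number from compound 1 to compound 2 (1.16 log units; beyond the scatter) is therefore only a bound.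

Compound 4 `COc1cc(-c2cccc3nc(-c4cccc(N)c4)oc23)cc(OC)c1OC` is not yet measured. It differs from compound 1 in one place: 3-aminophenyl in place of 3-fluoro-4-methoxyphenyl on an aromatic carbon.

The two measured steps that bear on this change both swap the same aryl group of the shared core. One, a 1.9-fold higher number from compound 1 to compound 3 (0.27 log units; within the scatter), stayed within the scatter; the other, an at least 14-fold higher number from compound 1 to compound 2 (1.16 log units; beyond the scatter), was a large loss. The new group has not been tried, so the expected step for compound 4 is a modest weakening, a 1.8-fold higher number from compound 1 to compound 4 (0.25 log units; within the scatter), with wide uncertainty. Compound 4 is estimated at 3000 nM, within a range from 600 nM to 15000 nM.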

Compound 4, half-maximal inhibitory concentration: 2200 nM
Beside the measured number, compound 4's estimate is 1.4-fold (0.13 log units) above it; the range from low to high includes it.
By their numbers in this assay, from the lowest: compounds 1, 4 and 3 (each within the scatter of the next). At a limit, above all of these: compound 2.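

In this assay, 3-aminophenyl is the only group shown with a hydrogen-bond donor, yet the swap costs nothing that can be read: a 1.3-fold higher number from compound 1 to compound 4 (0.11 log units; within the scatter), and a 1.5-fold lower number from compound 3 to compound 4 (0.16 log units; within the scatter). Three different aryl groups at this position now cannot be told apart, so a wide change in the group can be tolerated here, with the 4-bromophenyl of compound 2 as the one case that goes against this, shown by an at least 11-fold lower number from compound 2 to compound 4 (1.05 log units; beyond the scatter). That step is only a bound, since the value of compound 2 is a limit: the limit of > 25000 nM in this assay, at which 1 of the 4 values shown sits.

As far as these compounds go, whether the amine needs this exact place on the ring remains open, and 4-aminophenyl would test that. From the compounds shown here alone, it is also open whether 4-chlorophenyl or a carboxylic acid on the ring would stay level with these compounds or fall away like compound 2.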